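The compounds below may be only part of what the source reports. "The series", "measured", "known", "first", "only" and "open" are said of these compounds alone.

Three compounds carry the same amide to a difluorinated biphenyl. Compound 1 `Cc1ccc2nc(C(=O)Nc3c(F)cc(-c4cccc(F)c4)cc3F)c(C)c(O)c2c1` gives 56.4% in a functional assay on A-375 cells (Homo sapiens) for antiproliferative activity, read by MTT assay, with a stated time of 24 h, tested at 100 ug/mL (a higher number here means a stronger effect of the compound at the concentration tested, a lower number a weaker effect), compound 2 `CCc1ccc2nc(C(=O)Nc3c(F)cc(-c4cccc(F)c4)cc3F)c(C)c(O)c2c1` gives 47.3%, and compound 3 `CCOc1ccc2nc(C(=O)Nc3c(F)cc(-c4cccc(F)c4)cc3F)c(C)c(C(=O)O)c2c1` gives 72.4%, the highest of the three. The change hydrogen in place of methyl on a saturated chain carbon bound to an aromatic carbon moves the read-out by a number 9.1 percentage points higher from compound 2 to compound 1 (within the scatter). How the core of compound 3 differs from that of compound 2 is not broken down here. Compound 4 `COc1ccc2nc(C(=O)Nc3c(F)cc(-c4cccc(F)c4)cc3F)c(C)c(C(=O)O)c2c1` is not yet measured; it arises from compound 3 by hydrogen in place of methyl on a saturated chain carbon bound to an oxygen on an aromatic ring, the same kind of change as from compound 2 to compound 1, but at a saturated chain carbon bound to an oxygen on an aromatic ring rather than one bound to an aromatic carbon. Since the earlier step stayed within the scatter, the step expected here is a number 2.4 percentage points lower from compound 3 to compound 4 (within the scatter), small, resting on compound 1 at 56.4% against compound 2. Compound 4 is therefore estimated at 70%, between 55% and 85%.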

Compound 4, a percentage reported as inhibition, at one concentration (the size of the read-out at that concentration, not a potency): 58.7%
Beside the measured number, compound 4's estimate is 11.3 percentage points above it; low and high end bracket the measured number.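

In this assay, going from ethoxy to methoxy gives a number 13.7 percentage points lower from compound 3 to compound 4 (beyond the scatter). This change therefore does not carry over unchanged from one core to the other, and its effect on one core cannot be read across to the other: the same change on two cores in this assay, a number 9.1 percentage points higher (within the scatter) from compound 2 to compound 1 and a number 13.7 percentage points lower (beyond the scatter) from compound 3 to compound 4, 22.8 percentage points apart, beyond the scatter of two such steps. Going by these compounds alone, with only one pair on each core, the data do not show what produces this gap, since the changed chain carbon is bound to an aromatic carbon in one pair and to an oxygen on an aromatic ring in the other, and the cores differ as well.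

The compounds shown leave open how a longer chain such as propoxy, or an amine, would read in place of the ethoxy of compound 3. They also leave open how ethyl and methyl would compare on the core of compound 3.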